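Furan-2-yl in Place of 1-Benzofuran-2-yl: Three Limits

A few compounds are considered here, and "the series" means these few. Any claim that something is new, unique, unknown or untested is made for them only; others in the source may bear on it.

Compound 1 `O=c1[nH]cnc2c1c(-c1ccco1)cn2[C@@H]1O[C@H](CO)[C@@H](O)[C@H]1O` in a functional assay on HCT-116 cells (Homo sapiens), read by MTT assay, with a stated time of 72 h (a higher number here means a weaker inhibitor, a lower number a stronger inhibitor), gives > 20000 nM, which is a limit of the assay and not a number.
Compound 2 `O=c1[nH]cnc2c1c(-c1cc3ccccc3o1)cn2[C@@H]1O[C@H](CO)[C@@H](O)[C@H]1O` in this assay gives > 20000 nM, again a limit.
Compound 3 `CNc1ncnc2c1c(-c1cc3ccccc3o1)cn2[C@@H]1O[C@H](CO)[C@@H](O)[C@H]1O` in this assay gives > 20000 nM, also a limit.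

The change from compound 2 to compound 1 is furan-2-yl in place of 1-benzofuran-2-yl on an aromatic carbon, and the step it made, a step that the two limits leave unreadable from compound 2 to compound 1, cannot be read because the limit of > 20000 nM in this assay, at which 3 of the 3 values shown sit, holds both ends. The difference between the cores of compound 2 and compound 3 is not broken down here. Compound 4 `CNc1ncnc2c1c(-c1ccco1)cn2[C@@H]1O[C@H](CO)[C@@H](O)[C@H]1O` carries the same change relative to compound 3, namely (furan-2-yl in place of 1-benzofuran-2-yl on an aromatic carbon), at the same place.

Because the limit of > 20000 nM in this assay, at which 3 of the 3 values shown sit, shows every measured value sitting at that limit, the step from compound 3 to compound 4 is expected to be flat as well, a step that the limit leaves unreadable from compound 3 to compound 4. Compound 4 is therefore estimated to give about 30000 nM in this assay, likely reported as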

Compound 4, half-maximal inhibitory concentration: 440 nM
Compound 4: middle estimate off by 68-fold (1.83 log units), on the high side; measured number outside the range, below it.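

On the core of compound 3, furan-2-yl in place of 1-benzofuran-2-yl in this assay gives an at least 45-fold lower number from compound 3 to compound 4 (1.65 log units; beyond the scatter), so this change is far from silent on that core. The same change on the core of compound 2 cannot be read, because both of its ends sit at a limit of the assay, as does compound 3: the limit of > 20000 nM in this assay, at which 3 of the 4 values shown sit. For the compounds shown here, the data therefore neither show that the change carries over from one core to the other nor show that it fails to, as only one of the two steps has any readable size, and that size is only a minimum.

Going by these compounds, it remains open whether a thiophen-2-yl or a phenyl group at the same place on the core of compound 4 would also give a low number. Also open, on these data alone, is what a plain amine or a dimethylamino group would do in place of the methylamino group of compound 4.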